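A ring swap in a series stuck at its limit

The source may hold more compounds than are shown below. What is called first, only, known or untested is meant among the compounds shown, and "the series" means these compounds.

Compound 1 `O=C(Nc1cccc2cccnc12)c1ccc(F)nc1` gives > 10000 nM
Compound 2 `O=C(Nc1cccc2cccnc12)c1ccc(Br)cn1` gives > 10000 nM
Compound 3 `O=C(Nc1cccc2cccnc12)c1cccnn1` gives > 10000 nM

In a functional assay on BXPC-3 cells (Homo sapiens) for inhibition, read by MTT assay, with a stated time of 72 h (a lower number here means a stronger inhibitor, a higher number a weaker inhibitor), compound 3 gives > 10000 nM and this entry is a limit, not a number. Compound 1 and compound 2 also stop at a limit, and the whole set so far shows the limit of > 10000 nM in this assay, at which 3 of the 3 values shown sit, with no exact value among them. For the measured compounds named here, these entries therefore give no ranking, and no measured step is available to show how large a structural change might be.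

Compound 4 `O=C(Nc1cccc2cccnc12)c1ncccn1` keeps the shared core and has the same atoms as compound 3, joined differently (pyrimidin-2-yl in place of pyridazin-3-yl on a carbonyl carbon) with pyrimidin-2-yl in place of pyridazin-3-yl on a carbonyl carbon. Since compound 3 reads > 10000 nM as a limit, no step beyond the usual scatter is expected in this assay and neither direction is favoured. The expected step runs a step that the limit leaves unreadable from compound 3 to compound 4 and is small. For compound 4 the estimated value is 15000 nM with a range from 6000 nM to 40000 nM and a report of only a limit would be no surprise.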

Compound 4, half-maximal inhibitory concentration: > 10000 nM
Compound 4: no number, only a limit (the forecaster's own chance of this, stated with the estimate: 85%); the middle value is on the limit's open side.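

For the compounds shown here, compound 3 and compound 4 both stop at a limit rather than a number in this assay, so the swap of pyridazin-3-yl for pyrimidin-2-yl gives no step that can be read. The compounds shown leave open whether any group on the carbonyl carbon gives an exact value, and none yet ranks above another: the limit of > 10000 nM in this assay, at which 4 of the 4 values shown sit.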